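A few compounds are considered here, and "the series" means these few. Any claim that something is new, unique, unknown or untested is made for them only; others in the source may bear on it.

Measured compounds in a toxicity assay on HepG2 cells (Homo sapiens) for inhibition, read by CellTiter-Glo, with a stated time of 48 h; on this read-out lower numbers stand for stronger inhibition and higher numbers for weaker inhibition:

Compound 1 `COc1ccc2nc(C)cc(OCC(=O)Nc3cc(C)ccc3C)c2c1` gives a limit of > 100000 nM.
Compound 2 `COc1ccc2nc(C)cc(OCC(=O)Nc3c(C)cccc3C)c2c1` gives a limit of > 100000 nM.
Compound 3 `COc1ccc2nc(C)cc(OCC(=O)Nc3cccnc3)c2c1` gives a limit of > 100000 nM.

All three values sit at the same limit (the limit of > 100000 nM in this assay, at which 3 of the 3 values shown sit), so none of them is a number and no order among the compounds can be read. The step from compound 1 to compound 2 is a step that the two limits leave unreadable from compound 1 to compound 2; the step from compound 1 to compound 3 is a step that the two limits leave unreadable from compound 1 to compound 3; the step from compound 2 to compound 3 is a step that the two limits leave unreadable from compound 2 to compound 3. Compound 3 therefore stands at the limit, with nothing to separate it from the other two.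

Compound 4 `COc1ccc2nc(C)cc(OCC(=O)Nc3cc(C)nc(C)n3)c2c1` differs from compound 3 by 2,6-dimethylpyrimidin-4-yl in place of pyridin-3-yl on an amide-type nitrogen. Among the compounds with values here, the only steps that bear on it are the three changes of the group on the amide-type nitrogen, and all three are unreadable because every compound sits at the limit (the limit of > 100000 nM in this assay, at which 3 of the 3 values shown sit). No step beyond the scatter is expected from this change; the expected step is a step that the limit leaves unreadable from compound 3 to compound 4. Compound 4 is therefore estimated at 150000 nM, with a range from 50000 nM to 500000 nM, and most likely to be reported only as a limit.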

Compound 4, half-maximal inhibitory concentration: > 100000 nM
Compound 4: a limit, no number; the forecaster's own chance of this, stated with the estimate: 85%; the middle value is on the limit's open side.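

Compound 4 sits with compound 1, compound 2 and compound 3 at one shared limit, so no step among these four compounds can be read: the limit of > 100000 nM in this assay, at which 4 of the 4 values shown sit. The compounds shown leave open whether in this assay any change of the group on the amide-type nitrogen alters inhibition at all.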